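Compound 2 to compound 4: fluoro to cyclopentylcarbamoyl

A few compounds are considered here, and "the series" means these few. Any claim that something is new, unique, unknown or untested is made for them only; others in the source may bear on it.

In a functional assay on NCI-H1975 cells (Homo sapiens) for antiproliferative activity, read by CCK-8 assay, with a stated time of 72 h (a higher number here means a weaker inhibitor of growth, a lower number a stronger inhibitor of growth), compound 1 `CCCCNS(=O)(=O)c1ccc(Nc2ncc3c(n2)N(C2CCCC2)[C@H](CC)C(=O)N3C)cc1` gives 1610 nM and compound 3 `CCCNC(=O)c1ccc2c(ccn2-c2ncc3c(n2)N(C2CCCC2)[C@H](CC)C(=O)N3C)c1` gives 786 nM while compound 2 `CCC1C(=O)N(C)c2cnc(-n3ccc4cc(F)ccc43)nc2N1c1ccn(C)n1` gives 28600 nM as the highest number of the three. Compound 2 is therefore the weakest inhibitor of growth so far, and its gaps to compound 1 and compound 3 both lie beyond the scatter.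

Compound 4 `CCC1C(=O)N(C)c2cnc(-n3ccc4cc(C(=O)NC5CCCC5)ccc43)nc2N1c1ccn(C)n1` keeps the rest of compound 2 and changes one group. It has cyclopentylcarbamoyl in place of fluoro on an aromatic carbon of a six-membered aromatic ring of carbon only, part of a fused or bridged system of two rings.

Going by the values given here, no measured pair in the set differs in one place only, so this step has no direct precedent in this assay at present. The nearest guide is compound 3 (786 nM) which also carries an amide group but differs from compound 2 elsewhere as well, so only part of that gap is expected to carry over. The expected move is to a lower number and beyond the scatter, estimated as a 9.5-fold lower number from compound 2 to compound 4 (0.98 log units; beyond the scatter) in this read-out. For compound 4 the estimated value is 3000 nM with an expected range from 600 nM to 15000 nM for now.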

Compound 4, concentration for 50% growth inhibition: "not active" (no number reported)
For compound 4 the study gives words and no number, so the estimate cannot be set against anything.
By their numbers in this assay, from the lowest: compound 3; then compound 1; then compound 2.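

In this assay, going by these compounds alone, compound 4 is reported only in words, as not active, so no step from compound 2 at 28600 nM can be read. The compounds shown leave open how cyclopentylcarbamoyl in place of fluoro shifts growth inhibition on this scaffold. No evidence on hand bears on this result.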